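The source may report more compounds than this note shows. Statements on the series, on what has been measured and on what is new or still open speak of the compounds shown alone.

Compound 2 `COCCCc1nc(C(F)(F)F)ccc1CNC(=O)Nc1cccc2[nH]ncc12` is a urea bearing a 3-methoxypropyl chain on its pyridine-type ring. Among the compounds with values here, in a functional assay for antagonist activity at transient receptor potential cation channel subfamily V member 1 (Homo sapiens) (a lower number here means a stronger inhibitor, a higher number a weaker inhibitor), compound 2 gives 12 nM, the second highest of the three numbers known. Compound 1 `CC(C)(C)COc1nc(C(F)(F)F)ccc1CNC(=O)Nc1cccc2[nH]ncc12` gives 6 nM in this assay, and compound 3 `O=C(NCc1ccc(-c2ccccc2)nc1N1CCCCC1)Nc1cccc2[nH]ncc12` gives 14 nM; both differences to compound 2 lie within the scatter. Compound 4 `CC(C)(C)CCc1nc(C(F)(F)F)ccc1CNC(=O)Nc1cccc2[nH]ncc12` differs from compound 2 by tert-butyl in place of methoxymethyl on a saturated chain carbon, two bonds along the chain from an aromatic carbon. Within the data shown here, the one step that bears on this is a 2.0-fold higher number from compound 1 to compound 2 (0.30 log units; within the scatter), which shows that trading a branched, oxygen-free group for a methoxy-bearing chain changed little. Compound 4 moves back toward the branched pattern, so a small shift in this assay to a somewhat lower number is expected, not beyond the scatter. Compound 4 is estimated at 8 nM, within 3 nM to 25 nM, a step of a 1.5-fold lower number from compound 2 to compound 4 (0.18 log units; within the scatter) from compound 2.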

Compound 4, half-maximal inhibitory concentration: 5 nM
The estimate for compound 4 lay 1.6-fold (0.20 log units) above the measured number; measured number inside the range.
By their numbers in this assay, from the lowest: compounds 4, 1, 2 and 3 (each within the scatter of the next, the first and the last beyond it).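

In this assay, within the data shown here, putting tert-butyl in place of methoxymethyl at the end of the chain gives a 2.4-fold lower number from compound 2 to compound 4 (0.38 log units; beyond the scatter) and is the first step here to pass beyond the scatter, though only modestly. Exchanging neopentyloxy for 3,3-dimethylbutyl gives a 1.2-fold lower number from compound 1 to compound 4 (0.08 log units; within the scatter) so these two chains with a branched end read alike in this assay. The compounds shown leave open whether an amine or a carboxylic acid at the chain end, or a longer chain, would hold this level. Nothing given here explains why the step from methoxymethyl to tert-butyl occurs.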